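A Larger Bicyclic Group on a Weakly Active Core

The source may hold more compounds than are shown below. What is called first, only, known or untested is meant among the compounds shown, and "the series" means these compounds.

Compound 1 `Cc1c(-c2cc(Cl)cc(Cl)c2)c(C(=O)O)nn1-c1nc(-c2cccnc2)c(SC(C)C)s1` was tested in a functional assay on BJAB cells (Homo sapiens) for antiproliferative activity, with a stated time of 4 days (a lower number here means that less compound is needed, a higher number that more compound is needed for the effect), and gives "not active" (no number reported), so no number places it on the scale; it stands at the inactive end of what has been measured. A related compound, compound 2 `Cc1cccc(-c2c(C)nn(-c3nc(-c4ccc(Cl)c(Cl)c4)c(SC(C)C)s3)c2C(=O)O)c1`, differs from it in several places and in this assay gives 17000 nM, a weak effect. Compound 3 `Cc1c(-c2cc(Cl)cc(Cl)c2)c(C(=O)O)nn1-c1nc(-c2ccc3nccn3c2)c(SC(C)C)s1` has not yet been measured. It differs from compound 1 in one place: a group of 9 heavy atoms (7 carbon, 2 nitrogen; one five-membered aromatic ring with 2 hetero atoms, one six-membered aromatic ring with 1 hetero atom) in place of a group of 6 heavy atoms (5 carbon, 1 nitrogen; one six-membered aromatic ring with 1 hetero atom), on an aromatic carbon. Among the compounds with values here, no measured pair isolates this change, so the size and direction of the step in this assay cannot be set from the data; compound 1 gave no number to start from. A weak result, or again no measurable effect, seems the most plausible outcome. Compound 3 is therefore expected to give about 20000 nM in this assay, with a likely range from 4000 nM to 100000 nM, and a substantial chance that only inactivity is reported.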

Compound 3, half-maximal effective concentration: "not active" (no number reported)
Compound 3: no number reported; the estimate stays without a comparison.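

Compound 1 and compound 3 both come out without a number in this assay, so no step can be read for the change at this position, and no measurement at hand explains the result. From the compounds shown here alone, whether the larger group changes activity at all remains open.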